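From 2-(trifluoromethyl)benzyl to 2-cyanobenzyl

This account rests on a few compounds, and the source may have more. Where it says the series, first, only, none or still open, it means among the compounds named here.

Compound 1 `C=CCOc1ccc2c(=O)c(-c3cc(OC)c(OC)cc3OC)coc2c1`: 5100 nM
Compound 2 `COc1cc(OC)c(-c2coc3cc(OCc4ccccc4C(F)(F)F)ccc3c2=O)cc1OC`: 8550 nM

Both compounds were read in a functional assay on B16 cells (Mus musculus) for antiproliferative activity, read by MTT assay, with a stated time of 24 h; a lower number here means a stronger inhibitor, a higher number a weaker inhibitor. Compound 1 gives 5100 nM and compound 2 gives 8550 nM. Within the data shown here, these two values lie within the scatter of each other, so compound 2 does not stand apart from the only other measured compound.

Compound 3 `COc1cc(OC)c(-c2coc3cc(OCc4ccccc4C#N)ccc3c2=O)cc1OC` departs from compound 2 in one place: cyano in place of trifluoromethyl on an aromatic carbon.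

Among the measured compounds shown here, no measured step tests this exchange directly. For the measured compounds named here, the nearest evidence is the one step available, a 1.7-fold higher number from compound 1 to compound 2 (0.22 log units; within the scatter), where 2-(trifluoromethyl)phenyl replaced vinyl on the same chain. As far as these compounds go, that wider replacement stayed within the scatter, so no step beyond the scatter is expected in this assay, and the direction remains open. The estimated step is a 1.3-fold lower number from compound 2 to compound 3 (0.12 log units; within the scatter). Compound 3 is expected at 6500 nM, with an estimated range of 2800 nM to 15000 nM.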

Compound 3, half-maximal inhibitory concentration: 2140 nM
The estimate for compound 3 lay 3.0-fold (0.48 log units) above the measured number, outside the stated range (below it).
By their numbers in this assay, from the lowest: compound 3; then compounds 1 and 2 (each within the scatter of the next).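

In this assay, the group on an aromatic carbon ortho to a large group proves able to move the number: cyano in place of trifluoromethyl gives a 4.0-fold lower number from compound 2 to compound 3 (0.60 log units; beyond the scatter), a modest step but one beyond the scatter. Among these compounds, the earlier compounds could not show this, since the only step then available, a 1.7-fold higher number from compound 1 to compound 2 (0.22 log units; within the scatter), stayed within the scatter, whereas 2-cyanophenyl in place of vinyl on the same chain gives a 2.4-fold lower number from compound 1 to compound 3 (0.38 log units; beyond the scatter), so an aromatic ring at the end of this chain does not give one fixed outcome across these compounds. No measurement shown here accounts for the difference between cyano and trifluoromethyl at this place.

As far as these compounds go, with only these two groups compared on this aromatic carbon, it remains open whether the lower number belongs to cyano itself or follows from the loss of trifluoromethyl, and a plain hydrogen, a methoxy group, an amine or a carboxylic acid at the same place would help separate the two. From the compounds shown here alone, it also remains open whether the same exchange would give a similar step on a different chain or with a different substitution pattern on the shared core.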